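Working notes on cell cytotoxicity across four related compounds

The source may hold more compounds than are shown below. What is called first, only, known or untested is meant among the compounds shown, and "the series" means these compounds.

Measured so far:
Compound 1 `CCCCCCCc1c(C)nc2cc(OC)ccc2c1O`: > 34800 nM
Compound 2 `CCCCCCCc1c(C)nc2ccccc2c1O`: 5100 nM
Compound 3 `Cc1[nH]c2ccccc2c(=O)c1Br`: > 42000 nM

The read-out is an ADME assay on J774 cells (Mus musculus) for cytotoxicity; on this read-out higher numbers stand for an effect only at larger amounts of compound and lower numbers for an effect already at smaller amounts. Compound 2 gives a number, 5100 nM. Compound 1 gives only a limit in this assay, > 34800 nM. Compound 3 likewise gives only a limit, > 42000 nM. Among the compounds with values here, the one measured step is an at least 6.8-fold higher number from compound 2 to compound 1 (0.83 log units; beyond the scatter), and the change behind it is methoxy in place of hydrogen on an aromatic carbon. The difference between the cores of compound 2 and compound 3 is not broken down here.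

Compound 4 `COc1ccc2[nH]c(C)c(Br)c(=O)c2c1` is not yet measured. It differs from compound 3 by methoxy in place of hydrogen on an aromatic carbon, the same change at the same place as before. The step from compound 3 to compound 4 is expected to be a step that the limit leaves unreadable from compound 3 to compound 4 in this assay. That expectation rests on an at least 6.8-fold higher number from compound 2 to compound 1 (0.83 log units; beyond the scatter) and on compound 3 already sitting at a limit. Compound 4 is therefore estimated at 70000 nM, likely between 30000 nM and 200000 nM, most probably reported again only as a limit.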

Compound 4, half-maximal effective concentration: > 37300 nM
Compound 4 was reported as a limit; the forecaster's own chance of this, stated with the estimate: 85%; the middle value is on the limit's open side.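

No new step can be read: compound 3 and compound 4 are both reported only as limits in this assay. The compounds shown leave open whether methoxy in place of hydrogen changes the number at all on the core of compound 3.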